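This account rests on a few compounds, and the source may have more. Where it says the series, first, only, none or still open, it means among the compounds named here.

Of the compounds shown here, three have so far been measured in a functional assay on HeLa cells (Homo sapiens) for cytotoxicity, read by MTT assay, with a stated time of 48 h; a higher number here means a weaker inhibitor, a lower number a stronger inhibitor. Compound 1 `CC(C)=CC[C@H](OC(=O)C=C(C)C)C1=CC(=O)c2c(O)ccc(O)c2C1=O` gives 960 nM. Compound 2 `COc1ccc(O)c2c1C(=O)C=C(CCC=C(C)C)C2=O` gives 910 nM, and compound 3 `COc1ccc(O)c2c1C(=O)C=C([C@H](CC=C(C)C)OC(C)=O)C2=O` gives 660 nM, the lowest of the three numbers, though its gaps to compound 2 and to compound 1 both lie within the scatter. Among the measured compounds shown here, the only single-point step recorded is a 1.4-fold lower number from compound 2 to compound 3 (0.14 log units; within the scatter), which touches the same ester position that now changes. Compound 4 `COc1ccc(O)c2c1C(=O)C=C([C@H](CC=C(C)C)OC(=O)C=C(C)C)C2=O` differs from compound 3 as follows: 2-methylprop-1-en-1-yl in place of methyl on a carbonyl carbon. Compound 1 also carries the ((2-methylprop-1-en-1-yl)carbonyl)oxy group and sits close to compound 3 in value, so no step beyond the scatter is expected here. Compound 4 is estimated at 620 nM, between 300 nM and 1300 nM, which means an expected step of a 1.1-fold lower number from compound 3 to compound 4 (0.03 log units; within the scatter).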

Compound 4, half-maximal inhibitory concentration: 820 nM
For compound 4 the middle estimate is 1.3-fold (0.12 log units) below the measured one, and the stated range covers the measured number.
By their numbers in this assay, from the lowest: compounds 3, 4, 2 and 1 (each within the scatter of the next).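

In this assay the two esters on the chain carbon are not told apart: 2-methylprop-1-en-1-yl in place of methyl on the carbonyl carbon gives a 1.2-fold higher number from compound 3 to compound 4 (0.09 log units; within the scatter), and the larger ester also stays level with the unsubstituted chain, at a 1.1-fold lower number from compound 2 to compound 4 (0.05 log units; within the scatter), for its entry. With this ester held fixed, methyl in place of hydrogen on an oxygen on an aromatic ring gives a 1.2-fold lower number from compound 1 to compound 4 (0.07 log units; within the scatter), so neither place shows a step beyond the scatter. Nothing at hand bears on a cause for these results. On these data alone, whether an amine, a carboxylic acid or a longer acyl chain at this chain carbon would move the number beyond the scatter remains open.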